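Chloro in Place of Hydrogen: Cytotoxicity in a Small Series

The source may report more compounds than this note shows. Statements on the series, on what has been measured and on what is new or still open speak of the compounds shown alone.

Measured so far in a functional assay on HT-29 cells (Homo sapiens) for cytotoxicity, read by MTT assay, with a stated time of 24 h; a higher number here means a weaker inhibitor, a lower number a stronger inhibitor:
compound 1 `Cc1cc(-c2nc3cc(Cl)ccc3o2)ccc1NC(=O)CN1CCN(CCN(C)C)CC1` gives 13200 nM
compound 2 `Cc1cc(-c2nc3ccccc3o2)ccc1NC(=O)CN1CCN(CCN(C)C)CC1` gives 12900 nM
compound 3 `CN(C)CCCN1CCN(CC(=O)Nc2ccc(-c3nc4ccccc4o3)cc2)CC1` gives 10600 nM

These three values lie close together, within the usual scatter of repeated measurements, so none of the three can be called stronger or weaker than another. Compound 1 and compound 2 differ by one change, (chloro in place of hydrogen on an aromatic carbon), and that change made a step of a 1.0-fold higher number from compound 2 to compound 1 (0.01 log units; within the scatter). Compound 3 and compound 2 hold the same atoms joined differently; the difference between the two cores is not broken down here. Compound 4 `CN(C)CCCN1CCN(CC(=O)Nc2ccc(-c3nc4cc(Cl)ccc4o3)cc2)CC1` is not yet measured. It differs from compound 3 by chloro in place of hydrogen on an aromatic carbon, the same change as between compound 2 and compound 1, at the same place. Because the earlier step was a 1.0-fold higher number from compound 2 to compound 1 (0.01 log units; within the scatter), the expected step in this assay is a 1.0-fold higher number from compound 3 to compound 4 (0.01 log units; within the scatter), resting on that single earlier pair. Compound 4 is therefore estimated at 10800 nM, with a likely range from 5400 nM to 21600 nM.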

Compound 4, half-maximal inhibitory concentration: 1640 nM
Compound 4: middle estimate off by 6.6-fold (0.82 log units), on the high side; the whole stated range lies above it.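

In this assay, 5-chloro-1,3-benzoxazol-2-yl in place of 1,3-benzoxazol-2-yl gave compound 4 a clearly stronger result than compound 3 (a 6.5-fold lower number from compound 3 to compound 4 (0.81 log units; beyond the scatter)). The same change therefore did not carry over at the same size from one core to the other: the same change on two cores in this assay, a 1.0-fold higher number (0.01 log units; within the scatter) from compound 2 to compound 1 and a 6.5-fold lower number (0.81 log units; beyond the scatter) from compound 3 to compound 4, 6.6-fold (0.82 log units) apart, beyond the scatter of two such steps. This shows that, across these two pairs, the step from chloro depended on the core carrying it, but it does not show why, and two pairs give no rule for other cores.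

The compounds shown leave open which difference between the two cores matters, the extra methyl group or the length of the chain ending in the dimethylamino group. Also open, from the compounds shown here alone, is how a fluoro, bromo or methoxy group would compare with chloro at the same place on each core.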